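The source may hold more compounds than are shown below. What is called first, only, known or untested is meant among the compounds shown, and "the series" means these compounds.

Measured so far in an ADME assay on MT4 cells (Homo sapiens) for cytotoxicity, read by MTT assay, with a stated time of 4 days; on this read-out higher numbers stand for lower toxicity in this test and lower numbers for higher toxicity in this test:

Compound 1, `Cc1cc(-c2cc(Cl)cc(Cl)c2)cc(C)c1Nc1ccnc(Nc2ccc(C#N)cc2)n1`: 4290 nM
Compound 2, `Cc1cccc(-c2cc(C)c(Nc3ccnc(Nc4ccc(C#N)cc4)n3)c(C)c2)c1`: 3670 nM
Compound 3, `COc1cccc(-c2cc(C)c(Nc3ccnc(Nc4ccc(C#N)cc4)n3)c(C)c2)c1`: 2990 nM

Compound 2 stands second highest of these three numbers. Its nearest neighbour is compound 1, and its furthest is compound 3, yet both steps, a 1.2-fold lower number from compound 1 to compound 2 (0.07 log units; within the scatter) and a 1.2-fold lower number from compound 2 to compound 3 (0.09 log units; within the scatter), fall within the scatter of this assay, so the three measured compounds cannot be told apart on this read-out.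

Compound 4, `Cc1cc(-c2c(C)cccc2C)cc(C)c1Nc1ccnc(Nc2ccc(C#N)cc2)n1`, is not yet measured. It differs from compound 2 in one place: 2,6-dimethylphenyl in place of 3-methylphenyl on an aromatic carbon. The three measured steps all bear on this change, since each of them also alters the group attached at an aromatic carbon of the shared core: a 1.2-fold lower number from compound 1 to compound 2 (0.07 log units; within the scatter), a 1.4-fold lower number from compound 1 to compound 3 (0.16 log units; within the scatter) and a 1.2-fold lower number from compound 2 to compound 3 (0.09 log units; within the scatter). None of these moves the number beyond the scatter, even when two chlorines are exchanged for a single methyl or methoxy. The expectation for compound 4 is therefore a step of a 1.0-fold higher number from compound 2 to compound 4 (0.00 log units; within the scatter), that is, no shift beyond the scatter. Compound 4 is estimated at 3700 nM, with a range from 1800 nM to 7500 nM in this assay.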

Compound 4, half-maximal cytotoxic concentration: 2590 nM
Beside the measured number, compound 4's estimate is 1.4-fold (0.15 log units) above it; the range from low to high includes it.
By their numbers in this assay, from the lowest: compounds 4, 3, 2 and 1 (each within the scatter of the next).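

Compound 4 brings a 2,6-dimethylphenyl group to this position, meta to two methyl groups and para to a large group, a substitution pattern unlike those of the 3-methylphenyl, 3-methoxyphenyl and 3,5-dichlorophenyl groups, yet this assay shows only a 1.4-fold lower number from compound 2 to compound 4 (0.15 log units; within the scatter). The other two comparisons read the same way, with a 1.2-fold lower number from compound 3 to compound 4 (0.06 log units; within the scatter) and a 1.7-fold lower number from compound 1 to compound 4 (0.22 log units; within the scatter); the second of these is the largest step among the four compounds but is still within the scatter, so the set of four stays unresolved on this read-out even with this new pattern on the phenyl group. Nothing available here offers an explanation for these small differences.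

All four groups at this position are phenyl groups carrying only methyl, methoxy or chlorine, so the flat picture holds for those groups alone. As far as these compounds go, whether an amine or a carboxylic acid on this phenyl group, or a longer chain in its place, would move the number beyond the scatter remains open.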